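The source may hold more compounds than are shown below. What is called first, only, known or untested is meant among the compounds shown, and "the series" means these compounds.

Measured compounds:
compound 1, `CCCCNNC(=O)c1ccc(-c2ccc(CNC(C)=O)cc2)cc1`, in an assay on isolated protein for inhibition of histone deacetylase 8 (Homo sapiens), read by fluorescence, with a stated time of 5 min (a higher number here means a weaker inhibitor, a lower number a stronger inhibitor), compound 1 gives 360 nM.
compound 2, `CCCCCCNNC(=O)c1ccc(-c2ccc(CNC(C)=O)cc2)cc1`, in this assay compound 2 gives 36 nM.

Compound 2 stands at the lowest number of the two measured; the step to it from compound 1 is a 10-fold lower number from compound 1 to compound 2 (1.00 log units; beyond the scatter), beyond the scatter.

The next compound is compound 3, `CCCCCNNC(=O)c1ccc(-c2ccc(CNC(C)=O)cc2)cc1`, not yet measured in this assay. It differs from compound 2 by hydrogen in place of methyl on a saturated chain carbon, five bonds along the chain from an amine nitrogen. This change runs in the opposite direction to the step from compound 1 to compound 2 and is of the same kind, cut shorter, so that one measured step is the only one that bears on it; it was a 10-fold lower number from compound 1 to compound 2 (1.00 log units; beyond the scatter), and a part of that size, reversed, is the expectation here.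

The number for compound 3 in this assay is therefore expected to rise from that of compound 2 by a 3.1-fold higher number from compound 2 to compound 3 (0.49 log units; beyond the scatter). Compound 3 is estimated at 110 nM, with a range from 45 nM to 280 nM.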

Compound 3, half-maximal inhibitory concentration: 350 nM
Compound 3: middle estimate off by 3.2-fold (0.50 log units), on the low side, outside the stated range (above it).
By their numbers in this assay, from the lowest: compound 2; then compounds 3 and 1 (each within the scatter of the next).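

Hydrogen in place of methyl on a saturated chain carbon, five bonds along the chain from an amine nitrogen, gives a 9.7-fold higher number from compound 2 to compound 3 (0.99 log units; beyond the scatter) in this assay, so the gain is not spread evenly along the chain and the outermost carbon of compound 2 carries a step of about the same size as a 10-fold lower number from compound 1 to compound 2 (1.00 log units; beyond the scatter). Methyl in place of hydrogen, four bonds along the chain from an amine nitrogen, gives a 1.0-fold lower number from compound 1 to compound 3 (0.01 log units; within the scatter), which leaves compound 1 and compound 3 within the scatter of each other. No data on hand bear on why the step falls at this one carbon.

Going by these compounds, whether a longer chain extends the trend seen at compound 2 or reverses it stays open. So does whether a branched chain or a terminal phenyl can take the place of that outermost carbon.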